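The source may report more compounds than this note shows. Statements on the series, on what has been measured and on what is new or still open speak of the compounds shown alone.

Measured compounds:
compound 1, `C#CCNC(=O)/C(C)=C(\C)c1ccc(Br)cc1`: 18.4 mg/kg
compound 2, `C/C(C(=O)NC1CC1)=C(/C)c1ccc(F)cc1`: 25 mg/kg

Of the compounds shown here, two have been tested in a functional assay on the whole organism (strain Icem-CET (SPF Caw)) for inhibition, with Mus musculus as the target, with a stated time of 30 min; a higher number here means that more compound is needed for the effect, a lower number that less compound is needed. Compound 1 gives 18.4 mg/kg, and compound 2 gives 25 mg/kg. Of the two numbers, that of compound 2 is the larger one, but the gap between compound 2 and compound 1 is within the usual scatter of repeated measurements, so the two cannot be told apart on this evidence.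

Compound 3, `C/C(C(=O)NC1CC1)=C(/C)c1ccccc1`, has not yet been measured in this assay. It differs from compound 2 in one place: hydrogen in place of fluoro on an aromatic carbon. Among the compounds with values here, no pair of measured compounds shows what this change does, and the two numbers at hand differ from one another only within the scatter, so there is no basis for expecting a large step in either direction.

Compound 3 is therefore expected to come out close to compound 2, with a step of a 1.1-fold higher number from compound 2 to compound 3 (0.05 log units; within the scatter) that stays within the scatter. The estimate for compound 3 in this assay is 28 mg/kg, with a likely range from 12 mg/kg to 60 mg/kg.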

Compound 3, dose for half-maximal effect: 55.9 mg/kg
For compound 3 the middle estimate is 2.0-fold (0.30 log units) below the measured one, and the stated range covers the measured number.
By their numbers in this assay, from the lowest: compounds 1 and 2 (each within the scatter of the next); then compound 3.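

In this assay, within the data shown here, hydrogen in place of fluoro, on an aromatic carbon of a six-membered aromatic ring of carbon only and para to a large group, brings a 2.2-fold higher number from compound 2 to compound 3 (0.35 log units; beyond the scatter) and so gives the first step that can be read at this position. The earlier compounds shown here could not show this, as compound 1 and compound 2 differ in more than one place; the new pair shows that, with the rest of the structure held constant, the compound with fluoro at this position needs modestly less compound for the effect than the one with hydrogen. No measurement at hand bears on why this step occurs.

As far as these compounds go, the bromo group of compound 1 cannot be set beside fluoro or hydrogen at this position, since that compound also differs from compound 2 and compound 3 elsewhere, so any trend across these substituents remains unknown. From the compounds shown here alone, it also remains open whether a chloro, methyl or methoxy group at this position would match fluoro, and whether the step from fluoro to hydrogen would keep its size on the core of compound 1.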